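A few compounds are considered here, and "the series" means these few. Any claim that something is new, unique, unknown or untested is made for them only; others in the source may bear on it.

Compound 1 `CCCCOC(=O)NS(=O)(=O)c1sc(CC(C)C)cc1-c1ccc(CN2C(=O)CN(C)C2=O)cc1`: 68.6 nM in an assay on membranes from uterus for displacement of a labelled ligand from Angiotensin type II receptor (Sus scrofa), with a stated time of 1.5 h; a lower number here means a stronger inhibitor, a higher number a weaker inhibitor. Compound 2 `CCCCOC(=O)NS(=O)(=O)c1sc(CC(C)C)cc1-c1ccc(Cc2nnc(C(F)(F)F)o2)cc1`: 328 nM. Compound 3 `CCCCOC(=O)NS(=O)(=O)c1sc(CC(C)C)cc1-c1ccc(Cn2cnc(C(F)(F)F)c2)cc1`: 7.3 nM.

Compound 2 gives the highest number of the three; the nearest is compound 1, at a 4.8-fold higher number from compound 1 to compound 2 (0.68 log units; beyond the scatter), and the furthest is compound 3, at a 45-fold lower number from compound 2 to compound 3 (1.65 log units; beyond the scatter). Compound 4 `CCCCOC(=O)NS(=O)(=O)c1sc(CC(C)C)cc1-c1ccc(C(=O)c2cccs2)cc1` differs from compound 2 by a group of 7 heavy atoms (5 carbon, 1 oxygen, 1 sulfur; one five-membered aromatic ring with 1 hetero atom) in place of a group of 10 heavy atoms (4 carbon, 2 nitrogen, 1 oxygen, 3 fluorine; one five-membered aromatic ring with 3 hetero atoms), on an aromatic carbon, the incoming group being a (thiophen-2-yl)carbonyl on a six-membered aromatic ring of carbon only, para to a large group. Both known swaps at this position, a 4.8-fold higher number from compound 1 to compound 2 (0.68 log units; beyond the scatter) and a 45-fold lower number from compound 2 to compound 3 (1.65 log units; beyond the scatter), show that exchanging the 5-(trifluoromethyl)-1,3,4-oxadiazol-2-yl bearing group moves the number appreciably, and in both measured cases the alternative gave the lower number. A ketone-linked group has not been measured, so the expected step for compound 4 is taken as a lower number, modest in size, a 4.1-fold lower number from compound 2 to compound 4 (0.61 log units; beyond the scatter), with wide uncertainty. Compound 4 is thus estimated at 80 nM, between 15 nM and 400 nM.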

Compound 4, inhibition constant: 18.8 nM
For compound 4 the middle estimate is 4.3-fold (0.63 log units) above the measured one; low and high end bracket the measured number.
By their numbers in this assay, from the lowest: compound 3; then compound 4; then compound 1; then compound 2.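

The (thiophen-2-yl)carbonyl group shows that this position needs neither a nitrogen-bearing ring nor trifluoromethyl for a low number in this assay: the change gives a 17-fold lower number from compound 2 to compound 4 (1.24 log units; beyond the scatter) and a 3.6-fold lower number from compound 1 to compound 4 (0.56 log units; beyond the scatter). It does not fully match the best group here, with a 2.6-fold higher number from compound 3 to compound 4 (0.41 log units; beyond the scatter). Nothing available explains these differences.

Still open, from the compounds shown here alone, is which part of the new group matters: the carbonyl or the thiophene. A thiophen-2-ylmethyl group or a benzoyl group at this position would separate the two.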